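The source may hold more compounds than are shown below. What is called first, only, known or untested is meant among the compounds shown, and "the series" means these compounds.

Of the compounds shown here, three of one series have been tested in a functional assay on NIH3T3 cells (Mus musculus); on this read-out lower numbers stand for an effect already at smaller amounts and higher numbers for an effect only at larger amounts of compound. Compound 1 `CSCC[C@H](NC(=O)c1ccc(NCc2cncn2Cc2cccc(C)c2)cc1-c1ccccc1)C(=O)O` reaches only the limit of the measurement, giving > 10 uM in this assay. Compound 2 `CSCC[C@H](NC(=O)c1ccc(NCc2cncn2Cc2ccc(C#N)cc2)cc1-c1ccccc1)C(=O)O`, which carries 4-cyanophenyl in place of 3-methylphenyl on a saturated chain carbon bound to an aromatic nitrogen, likewise stops at a limit, > 10 uM. The step between them, a step that the two limits leave unreadable from compound 1 to compound 2, therefore has no readable size. Compound 3 `COC(=O)[C@H](CCSC)NC(=O)c1ccc(NCc2cncn2Cc2ccc(Cl)cc2)cc1-c1ccccc1` is the methyl ester of the shared acid; in this assay compound 3 also stands only at a limit, > 10 uM. For the measured compounds named here, all three values sit at the limit of > 10 uM in this assay, at which 3 of the 3 values shown sit, so no measured step within this set can be read.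

Compound 4 `CSCC[C@H](NC(=O)c1ccc(NCc2cncn2Cc2ccc(Cl)cc2)cc1-c1ccccc1)C(=O)O` is the acid that belongs to compound 3; the change is hydrogen in place of methyl on an oxygen next to a carbonyl group. Going by the values given here, compounds 1 and 2 already carry the carboxy group and both stop at the limit, so the ester-to-acid change has no measured counterpart here whose size could guide the expectation. Given that compound 3 itself gives only a limit, > 10 uM, compound 4 is expected to remain at or near that limit, a step that the limit leaves unreadable from compound 3 to compound 4 that is not expected to exceed the scatter. The estimate for compound 4 in this assay is 20 uM, with a range from 7 uM to 60 uM, and the assay is most likely to report only a limit once more.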

Compound 4, concentration for half-maximal effect: > 10 uM
Compound 4 gave a limit, no number (the forecaster's own chance of this, stated with the estimate: 80%); the middle value is on the limit's open side.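

Compound 4 gives only a limit in this assay, > 10 uM. The steps to it from compound 1, compound 2 and compound 3 therefore cannot be read: the limit of > 10 uM in this assay, at which 4 of the 4 values shown sit. The compounds shown leave open how far each lies beyond that limit, and whether the methyl ester, the acid or the different aryl groups differ at all in this assay.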